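From isopropyl to neopentyl on the carbonyl carbon

A few compounds are considered here, and "the series" means these few. Any claim that something is new, unique, unknown or untested is made for them only; others in the source may bear on it.

Compound 1 `Cc1cc(C(N)=O)nn1Cc1cc(Cl)ccc1OCc1ccccc1` gives 126 nM in an assay on CHO-K1 cells for displacement of a labelled ligand from prostaglandin E2 receptor EP1 subtype (Homo sapiens); on this read-out higher numbers stand for weaker inhibition and lower numbers for stronger inhibition. For the measured compounds named here, compound 2 `Cc1cc(NC(=O)C(C)C)nn1Cc1cc(Cl)ccc1OCc1ccccc1`, which carries (isopropylcarbonyl)amino in place of carbamoyl on an aromatic carbon, gives 25.1 nM in this assay; the step of a 5.0-fold lower number from compound 1 to compound 2 (0.70 log units; beyond the scatter) is the only measured one, and compound 2 therefore stands at the lowest of the two numbers so far.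

Compound 3 `Cc1cc(NC(=O)CC(C)(C)C)nn1Cc1cc(Cl)ccc1OCc1ccccc1` differs from compound 2 by neopentyl in place of isopropyl on a carbonyl carbon. Going by the values given here, no measured step concerns an exchange of one alkyl group for another on that carbonyl carbon; the step of a 5.0-fold lower number from compound 1 to compound 2 (0.70 log units; beyond the scatter) describes a different change and bears on it only as a sign that the amide-type nitrogen with an alkylcarbonyl group is tolerated. For compound 3 in this assay no step beyond the scatter is therefore expected, and the estimate is 25 nM, between 8 nM and 80 nM, a step of a 1.0-fold lower number from compound 2 to compound 3 (0.00 log units; within the scatter).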

Compound 3, half-maximal inhibitory concentration: 10 nM
Estimate against measurement, compound 3: 2.5-fold (0.40 log units) above, within the range that was stated.
By their numbers in this assay, from the lowest: compound 3; then compound 2; then compound 1.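

In this assay the carbonyl carbon bonded to the amide-type nitrogen turns out to be sensitive to the choice of alkyl group, since neopentyl in place of isopropyl gives a 2.5-fold lower number from compound 2 to compound 3 (0.40 log units; beyond the scatter) and the two groups are therefore not interchangeable on this read-out. Measured against the carbamoyl group, the (neopentylcarbonyl)amino group gives a 13-fold lower number from compound 1 to compound 3 (1.10 log units; beyond the scatter) and so makes a large step where the (isopropylcarbonyl)amino group made only a modest one. No evidence is available to explain the difference between the two alkyl groups.

With only two alkyl groups on this carbonyl carbon, the compounds shown leave open whether the number keeps falling with a longer chain such as n-hexyl. They also leave open how a cyclohexyl ring or an amine in the same place would read.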